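Replacing the acetyl aryl group with a methylsulfanyl aryl group

A few compounds are considered here, and "the series" means these few. Any claim that something is new, unique, unknown or untested is made for them only; others in the source may bear on it.

For the measured compounds named here, compound 3 `CC(=O)c1cccc(N/C(=N/[C@@H]2c3cc(C#N)ccc3OC(C)(C)[C@H]2O)NC#N)c1` stands at the high end of the numbers so far in a functional assay (aorta) with Rattus norvegicus as the target; on this read-out lower numbers stand for stronger inhibition and higher numbers for weaker inhibition: compound 3 gives 8400 nM. Going by the values given here, its nearest neighbour is compound 2 `CC1(C)Oc2ccc(C#N)cc2[C@@H](/N=C(\NC#N)Nc2cccc([N+](=O)[O-])c2)[C@@H]1O`, which in this assay gives 670 nM; the single one-place step between them, acetyl in place of nitro on an aromatic carbon, reads a 13-fold higher number from compound 2 to compound 3 (1.10 log units; beyond the scatter). Compound 1 `CC1(C)Oc2ccc(C#N)cc2[C@@H](/N=C(\NC#N)Nc2ccccc2)[C@@H]1O` gives 1400 nM; 1300 nM (2 entries) in this assay, and its repeated entries agree closely (the several entries of compound 1 in this assay, 1400 nM; 1300 nM (2 entries)), which shows that this read-out is reproducible here.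

Compound 4 `CSc1ccc(N/C(=N/[C@@H]2c3cc(C#N)ccc3OC(C)(C)[C@H]2O)NC#N)cc1` is the next step from compound 3. The change is 4-(methylsulfanyl)phenyl in place of 3-acetylphenyl on an amine nitrogen. Among the compounds with values here, no measured step covers this exchange directly; the only one that bears on it is the acetyl-for-nitro step, which was large, and the value of compound 1 shows that the set without the acetyl sits well below compound 3. Within the data shown here, removing the acetyl is therefore expected to lower the number, while the methylsulfanyl group has no precedent in the set, so the expected step is moderate and uncertain. Compound 4 is estimated at 2000 nM with a range from 700 nM to 6000 nM in this assay. The expected step is a 4.2-fold lower number from compound 3 to compound 4 (0.62 log units; beyond the scatter), toward stronger inhibition.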

Compound 4, half-maximal inhibitory concentration: 6300 nM
Beside the measured number, compound 4's estimate is 3.2-fold (0.50 log units) below it, outside the stated range (above it).
By their numbers in this assay, from the lowest: compound 2; then compounds 4 and 3 (each within the scatter of the next).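

In this assay, the exchange on the amine nitrogen gives a 1.3-fold lower number from compound 3 to compound 4 (0.12 log units; within the scatter), so 4-(methylsulfanyl)phenyl and 3-acetylphenyl cannot be told apart on this read-out, although the two groups differ both in the substituent and in its place on the aromatic ring. Measured against 3-nitrophenyl, the new group gives a 9.4-fold higher number from compound 2 to compound 4 (0.97 log units; beyond the scatter), and the acetyl group gives a 13-fold higher number from compound 2 to compound 3 (1.10 log units; beyond the scatter), so neither exchange keeps the low number of the nitro compound. The match between the acetyl and methylsulfanyl compounds is read on an assay that repeats closely, and the large gap of each to the nitro compound is read on the same footing: the several entries of compound 1 in this assay, 1400 nM; 1300 nM (2 entries)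

Open, from the compounds shown here alone, is whether the substituent itself or its place on the ring sets the number, as the step from 3-acetylphenyl to 4-(methylsulfanyl)phenyl changes both at once. Also open, going by these compounds, is how an aromatic ring carrying an amine or a carboxylic acid would read on this amine nitrogen, and whether a longer alkyl chain could stand in place of the aromatic ring.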